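Hydroxy to tert-butyl: what to expect for compound 4

A few compounds are considered here, and "the series" means these few. Any claim that something is new, unique, unknown or untested is made for them only; others in the source may bear on it.

Compound 3 `Oc1cccc(Nc2nc(-c3ccncc3)cs2)c1` gives 28800 nM in a functional assay on RCC4 cells (Homo sapiens) for inhibition, read by XTT assay, with a stated time of 4 days (a lower number here means a stronger inhibitor, a higher number a weaker inhibitor), the highest of the two plain numbers here. Its nearest neighbour is compound 1 `Cc1ccc(Nc2nc(-c3ccncc3)cs2)cc1O`, which in this assay gives 12000 nM. Compound 2 `Cc1cccc(Nc2nc(-c3ccncc3N3CCN(C)CC3)cs2)c1` gives 2600 nM; 2630 nM (2 entries) in this assay, as seen in the several entries of compound 2 in this assay, 2600 nM; 2630 nM (2 entries), but no single change links it to compound 3. Compound 4 `CC(C)(C)c1cccc(Nc2nc(-c3ccncc3)cs2)c1` differs from compound 3 by tert-butyl in place of hydroxy on an aromatic carbon. For the measured compounds named here, only one measured step bears on this change, and loosely: a 2.4-fold higher number from compound 1 to compound 3 (0.38 log units; beyond the scatter), where losing a methyl raised the number modestly. On that basis, replacing the hydroxy with a larger alkyl is expected to lower the number. Compound 4 is therefore estimated at about 8000 nM in this assay, within 2000 nM to 30000 nM. That expectation amounts to a 3.6-fold lower number from compound 3 to compound 4 (0.56 log units; beyond the scatter).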

Compound 4, half-maximal inhibitory concentration: 60300 nM
Beside the measured number, compound 4's estimate is 7.5-fold (0.88 log units) below it; measured number outside the range, above it.
By their numbers in this assay, from the lowest: compound 1; then compound 3; then compound 4.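

In this assay, tert-butyl in place of hydroxy on an aromatic carbon, meta to a large group, gives a 2.1-fold higher number from compound 3 to compound 4 (0.32 log units; beyond the scatter) and so does not lower the number. Adding alkyl carbon therefore does not go with a lower number across these compounds: losing a methyl gave a 2.4-fold higher number from compound 1 to compound 3 (0.38 log units; beyond the scatter) and gaining tert-butyl at this other place also raised it. As far as these compounds go, whether an amine or a methoxy group at this place would give a lower number than hydroxy or tert-butyl stays open. Nothing shown here offers a measured reason for this step.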